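The compounds below may be only part of what the source reports. "The series", "measured", "known", "first", "only" and "open" are said of these compounds alone.

Measured so far in a functional assay on SK-OV-3 cells (Homo sapiens) for antiproliferative activity, read by MTT assay; on this read-out higher numbers stand for weaker inhibition and lower numbers for stronger inhibition:

- compound 1 `CCCOC(=O)N1CCCc2cc(S(=O)(=O)N3CC(c4ccccc4)NC3=O)ccc21` gives 3920 nM
- compound 2 `C=CCOC(=O)N1CCCc2cc(S(=O)(=O)N3CC(c4ccccc4)NC3=O)ccc21` gives 2750 nM

For the measured compounds named here, with only these two numbers, compound 1 stands level with compound 2, its sole neighbour on the scale. The next candidate is compound 3 `O=C(c1ccccc1)N1CCCc2cc(S(=O)(=O)N3CC(c4ccccc4)NC3=O)ccc21`, which has not yet been measured. Its difference from compound 1 is phenyl in place of propoxy on a carbonyl carbon. Put simply, phenyl takes the place of propoxy on a carbonyl carbon, turning propoxycarbonyl into benzoyl.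

Going by the values given here, only one measured step bears on this change, and only loosely: a 1.4-fold lower number from compound 1 to compound 2 (0.15 log units; within the scatter). That step exchanged just part of the chain, whereas here the whole propoxy leaves and a ring enters. Among the compounds with values here, it therefore offers no direction for the new change, and the data hold no other compound with a ring in this place. No step beyond the scatter is firmly expected in this assay, although a larger move either way remains possible. The expected change is a 1.6-fold lower number from compound 1 to compound 3 (0.20 log units; within the scatter). For compound 3 the estimated value is 2500 nM, with an expected range of 700 nM to 9000 nM.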

Compound 3, half-maximal inhibitory concentration: 8560 nM
Compound 3: the middle estimate sits 3.4-fold (0.53 log units) below what was measured; the range from low to high includes it.
By their numbers in this assay, from the lowest: compounds 2 and 1 (each within the scatter of the next); then compound 3.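

Replacing propoxy with phenyl on the carbonyl carbon, which turns propoxycarbonyl into benzoyl, gives a 2.2-fold higher number from compound 1 to compound 3 (0.34 log units; beyond the scatter) in this assay and so moves the number beyond the usual scatter toward weaker inhibition, which the earlier change within the chain did not do. The comparison with the allyloxy group points the same way, with a 3.1-fold higher number from compound 2 to compound 3 (0.49 log units; beyond the scatter) also beyond the scatter, so among these three compounds the two carrying an oxygen-linked chain on this carbonyl carbon both inhibit more strongly than the one carrying a phenyl ring, though only modestly. Nothing available explains this shift.

The compounds shown change two things at once, the oxygen link and the ring, and so leave open which of them goes with the weaker inhibition: a benzyloxy group on the same carbonyl carbon would keep the link together with a ring, while a pentyl chain would have neither. Also open, from the compounds shown here alone, is how an amine on this carbonyl carbon, such as dimethylamino, or a phenyl ring bearing a substituent, would compare with the groups seen so far.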